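The source may report more compounds than this note shows. Statements on the series, on what has been measured and on what is new or still open speak of the compounds shown alone.

The measured compounds:

compound 1, `COc1cc(F)c(NC(=O)c2ccncc2)cc1Nc1nccc(-c2cn(C)c3ccccc23)n1`, in a functional assay on A549 cells (Homo sapiens) for antiproliferative activity, read by MTT assay, with a stated time of 72 h; on this read-out higher numbers stand for weaker inhibition and lower numbers for stronger inhibition: 4200 nM
compound 2, `COc1cc(F)c(NC(=O)c2ccnc(Cl)c2)cc1Nc1nccc(-c2cn(C)c3ccccc23)n1`, in this assay : 6890 nM
compound 3, `COc1cc(N(C)CCN(C)C)c(NC(=O)c2ccncc2)cc1Nc1nccc(-c2cn(C)c3ccccc23)n1`, in this assay : 10400 nM

Compound 3 stands apart from compound 1 by a 2.5-fold higher number from compound 1 to compound 3 (0.39 log units; beyond the scatter), a modest step beyond the scatter, while its gap to compound 2 is within the scatter, so the two cannot be ordered. Compound 4, `COc1cc(N(C)CCN(C)C)c(NC(=O)c2ccnc(Cl)c2)cc1Nc1nccc(-c2cn(C)c3ccccc23)n1`, is unmeasured; it differs from compound 3 by chloro in place of hydrogen on an aromatic carbon. For the measured compounds named here, the one measured step that bears on this change is the same substitution made on compound 1, a 1.6-fold higher number from compound 1 to compound 2 (0.21 log units; within the scatter), which stayed within the scatter. On that basis the step for compound 4 is expected to be small, a 1.4-fold higher number from compound 3 to compound 4 (0.16 log units; within the scatter), with a lean towards a higher number but not beyond the scatter. Compound 4 is therefore estimated at 15000 nM in this assay, with a range from 7000 nM to 35000 nM.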

Compound 4, half-maximal inhibitory concentration: 970 nM
The estimate for compound 4 lay 15-fold (1.19 log units) above the measured number; the measured number lies below the stated range.
By their numbers in this assay, from the lowest: compound 4; then compounds 1, 2 and 3 (each within the scatter of the next, the first and the last beyond it).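

In this assay, chloro in place of hydrogen next to the ring nitrogen gives an 11-fold lower number from compound 3 to compound 4 (1.03 log units; beyond the scatter) on the core carrying the (2-(dimethylamino)ethyl)(methyl)amino group, so the outcome at this position depends on the rest of the molecule: the same change on two cores in this assay, a 1.6-fold higher number (0.21 log units; within the scatter) from compound 1 to compound 2 and an 11-fold lower number (1.03 log units; beyond the scatter) from compound 3 to compound 4, 18-fold (1.25 log units) apart, beyond the scatter of two such steps.
Read from the other side, the same pair shows a 7.1-fold lower number from compound 2 to compound 4 (0.85 log units; beyond the scatter) and so reverses the direction that this amino group gave without the chloro: the same change on two cores in this assay, a 2.5-fold higher number (0.39 log units; beyond the scatter) from compound 1 to compound 3 and a 7.1-fold lower number (0.85 log units; beyond the scatter) from compound 2 to compound 4, 18-fold (1.25 log units) apart, beyond the scatter of two such steps.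
The two changes therefore do not act independently in this assay, and neither step predicts the other.

The compounds shown leave open whether methyl or methoxy in place of the chloro would give a similar step alongside the amino group. They also leave open whether a smaller amine, such as dimethylamino, would keep the step seen with the chloro.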